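Selenium Methyl Removal on a Cytotoxicity Limit

The source may hold more compounds than are shown below. What is called first, only, known or untested is meant among the compounds shown, and "the series" means these compounds.

Compound 1 `COc1ccc(CNc2nc([Se]C)nc3ccccc23)cc1`: in a functional assay on HT-29 cells (Homo sapiens) for cytotoxicity, read by MTT assay, with a stated time of 72 h (on this read-out lower numbers stand for higher toxicity in this test and higher numbers for lower toxicity in this test), compound 1 gives > 100000 nM, which is a limit of the assay and not a number.
Compound 2 `C[Se]c1nc(N)c2ccccc2n1`: in this assay compound 2 gives > 100000 nM, again a limit of the assay.

Within the data shown here, compound 1 therefore stands at the limit of > 100000 nM in this assay, at which 2 of the 2 values shown sit, so no ordering between the two measured compounds can be read, and no step between measured compounds is available.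

Compound 3 `COc1ccc(CNc2nc([SeH])nc3ccccc23)cc1` differs from compound 1 by hydrogen in place of methyl on a selenium. Nothing measured here tells how this change acts in this assay. The step of a number no higher from compound 1 to compound 3 (the limit leaves the size open) is expected to be none beyond the usual scatter, since compound 1 sits at the limit > 100000 nM and only a large gain in toxicity would move a value off it. Compound 3 is therefore expected at about 100000 nM, within 30000 nM to 300000 nM, and most probably reported once more as a limit.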

Compound 3, concentration lethal to 50% of the cells: > 100000 nM
Compound 3: only a limit was reported; the forecaster's own chance of this, stated with the estimate: 80%; the middle value lies on the limit itself.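

No step can be read from compound 1 to compound 3, since both results are limits of this assay and not numbers: (the limit of > 100000 nM in this assay, at which 3 of the 3 values shown sit). The compounds shown leave open whether hydrogen in place of methyl on a selenium changes the cytotoxicity of compound 1 at all.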